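The source may hold more compounds than are shown below. What is called first, only, known or untested is meant among the compounds shown, and "the series" means these compounds.

Measured so far:
- compound 1 `COc1ccc2nc3c(nc2c1)O[C@H]1CN(C(=O)[C@H](C(C)(C)C)NC(=O)O[C@@H]2C[C@H]2CCCCC3)[C@H](C(=O)N[C@]2(C(=O)NS(=O)(=O)C3(C)CC3)C[C@H]2C(F)F)[C@@H]1C`: 100%
- compound 2 `CC[C@@H]1[C@@H]2CN(C(=O)[C@H](C(C)(C)C)NC(=O)O[C@@H]3C[C@H]3CCCCCc3nc4ccc(OC)cc4nc3O2)[C@@H]1C(=O)N[C@]1(C(=O)NS(=O)(=O)C2CC2)C[C@H]1CC`: 100%

In an ADME assay on the whole organism (Rattus norvegicus) for pharmacokinetics (on this read-out higher numbers stand for higher oral bioavailability and lower numbers for lower oral bioavailability), compound 2 gives 100%, level with compound 1 within the scatter. Compound 3 `CC[C@@H]1[C@@H]2CN(C(=O)[C@H](C(C)(C)C)NC(=O)O[C@@H]3C[C@H]3CCCCCc3nc4ccc(OC)cc4nc3O2)[C@@H]1C(=O)N[C@]1(C(=O)NS(=O)(=O)C2CC2)C[C@H]1C(F)F` follows from compound 2 by one change, difluoromethyl in place of ethyl on a saturated ring carbon. Among the compounds with values here, no measured pair isolates this change, so the data give no direct size for it. Compound 1 also bears difluoromethyl on a three-membered ring and gives 100%, so a large loss is not expected. Compound 2 at 100% leaves no room for a rise on this read-out, so any expected movement points downward. The expected change is a moderate fall, a number 15 percentage points lower from compound 2 to compound 3 (beyond the scatter). For compound 3 the estimated value is 85%, with an expected range of 55% to 100%.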

Compound 3, oral bioavailability: 36%
Estimate against measurement, compound 3: 49 percentage points above; the measured number lies below the stated range.
By their numbers in this assay, from the lowest: compound 3; then compounds 1 and 2 (each within the scatter of the next).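

In this assay, difluoromethyl in place of ethyl on a saturated ring carbon of the three-membered ring gives a number 64 percentage points lower from compound 2 to compound 3 (beyond the scatter), a large step that shows oral bioavailability in this series depends on the group held at this position. Compound 1 also carries difluoromethyl there and gives 100%, but it differs from compound 3 in more than one place, so difluoromethyl at this position is not poorly tolerated in every setting shown, and the size of the step holds only for the background of compound 2. Nothing available explains the fall.

Still open, from the compounds shown here alone, is whether a propyl or trifluoromethyl group at this position would stand nearer compound 2 or compound 3. The ethyl counterpart of compound 1 would show whether the step carries over to that background.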